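A Bicyclic Amide in Place of the Difluorocyclohexyl Group

The source may hold more compounds than are shown below. What is called first, only, known or untested is meant among the compounds shown, and "the series" means these compounds.

Compound 1 `O=C(C1CCC(F)(F)CC1)N1CC(c2nc(-c3cccc(Cl)c3)no2)C1` carries a 4,4-difluorocyclohexyl group on the carbonyl carbon of its amide. Going by the values given here, in an assay on HEK293 cells for positive allosteric modulation of metabotropic glutamate receptor 5 (Homo sapiens), read by FLIPR (a higher number here means that more compound is needed for the effect, a lower number that less compound is needed), compound 1 gives 180 nM, the only actual number among the three measured compounds. Compound 2 `O=S(=O)(c1ccc(Cl)cc1)N1CC(c2nc(-c3cccc(Cl)c3)no2)C1`, a sulfonamide analogue of the shared core, reaches in this assay only a limit of the assay, > 10000 nM. Compound 3 `Cc1cccc(-c2noc(C3CN(C(=O)c4ccccc4F)C3)n2)c1` likewise sits in this assay at a limit, > 10000 nM. Two of the three values therefore stand at the limit of > 10000 nM in this assay, at which 2 of the 3 values shown sit, so compound 1 alone anchors the series with a number.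

Compound 4 `O=C([C@@H]1CC2CCC1C2)N1CC(c2nc(-c3cccc(Cl)c3)no2)C1` differs from compound 1 in one place: a group of 7 heavy atoms (7 carbon; 2 five-membered non-aromatic rings of carbon only) in place of a group of 8 heavy atoms (6 carbon, 2 fluorine; one six-membered non-aromatic ring of carbon only), on a carbonyl carbon. Among the compounds with values here, no measured pair spans a change of this kind, so nothing in the data fixes the size of the step. Because compound 1 gives 180 nM and the amide is kept, compound 4 is expected to give about 220 nM, with a range from 70 nM to 700 nM. The step of a 1.2-fold higher number from compound 1 to compound 4 (0.09 log units; within the scatter) is thus estimated to stay within the scatter, in no clear direction.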

Compound 4, half-maximal effective concentration: 98 nM
The estimate for compound 4 lay 2.2-fold (0.35 log units) above the measured number; the measured number falls inside the stated range.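

In this assay, the group on the carbonyl carbon can be exchanged without leaving the scatter: replacing the 4,4-difluorocyclohexyl group with a group of two five-membered carbon rings gives a 1.8-fold lower number from compound 1 to compound 4 (0.26 log units; within the scatter) and so no clear change. Going by these compounds alone, until now only one group at this position had a number, and compound 4 adds a second, which shows that neither the two fluorine atoms nor the six-membered ring is required for a measurable value in this assay. Nothing in the data shown accounts for the two values lying within the scatter of each other.

From the compounds shown here alone, what a plain cyclohexyl group, or a cyclohexyl group carrying an amine, would give on this carbonyl carbon remains open. Also open, going by these compounds, is whether the defined stereocentre of compound 4 matters.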